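Series notes: aryl amine change from compound 3 to compound 4

This account rests on a few compounds, and the source may have more. Where it says the series, first, only, none or still open, it means among the compounds named here.

Among the measured compounds shown here, compound 3 `CN(c1cccc2c1CN(c1nc(Nc3ccc(Cl)c(C(F)(F)F)c3)ncc1C(F)(F)F)C2)S(C)(=O)=O` is the only member of the set with a measured number: in a functional assay on A549 cells (Homo sapiens) for antiproliferative activity, read by spectrophotometry, with a stated time of 2 days (on this read-out lower numbers stand for stronger inhibition of growth and higher numbers for weaker inhibition of growth), compound 3 gives 15200 nM. Compound 1 `COc1ccc(Nc2ncc(C(F)(F)F)c(N3Cc4cccc(N(C)S(C)(=O)=O)c4C3)n2)cc1C(F)(F)F` in this assay gives > 30000 nM, which is a limit of the assay and not a number. Compound 2 `CN(c1cccc2c1CN(c1nc(Nc3ccc(C(F)(F)F)cc3)ncc1C(F)(F)F)C2)S(C)(=O)=O` in this assay gives > 30000 nM, again a limit. Two of the three values therefore sit at the limit of > 30000 nM in this assay, at which 2 of the 3 values shown sit. The steps toward compound 3 read an at least 1.9-fold lower number from compound 1 to compound 3 (0.29 log units; that floor lies within the scatter) and an at least 1.9-fold lower number from compound 2 to compound 3 (0.29 log units; that floor lies within the scatter), while the step that the two limits leave unreadable from compound 1 to compound 2 cannot be read. Compound 3 thus holds the single number shown, with both neighbours at the limit.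

Compound 4 `COc1cc(Nc2ncc(C(F)(F)F)c(N3Cc4cccc(N(C)S(C)(=O)=O)c4C3)n2)cc(OC)c1` differs from compound 3 by 3,5-dimethoxyphenyl in place of 4-chloro-3-(trifluoromethyl)phenyl on a nitrogen on an aromatic ring. For the measured compounds named here, no measured step covers this change directly. The closest point of reference is compound 1, which carries 4-methoxy-3-(trifluoromethyl)phenyl on the same nitrogen and in this assay gives > 30000 nM, a limit. With both the chloro and the trifluoromethyl gone and two methoxy groups in their place, the number for compound 4 is expected to move back toward that limit, an expected step of a 2.0-fold higher number from compound 3 to compound 4 (0.30 log units; within the scatter). Compound 4 is therefore estimated at 30000 nM, within a range from 10000 nM to 90000 nM, with a real chance that only a limit is reported.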

Compound 4, concentration for 50% growth inhibition: 24800 nM
Estimate against measurement, compound 4: 1.2-fold (0.08 log units) above, and the stated range covers the measured number.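

At this nitrogen in this assay, the change to 3,5-dimethoxyphenyl gives a 1.6-fold higher number from compound 3 to compound 4 (0.21 log units; within the scatter), so a measured number short of the limit is no longer tied to the 4-chloro-3-(trifluoromethyl)phenyl group alone: a group with neither chloro nor trifluoromethyl also gives one. Against the other two aryl amines, the readable steps are only floors, an at least 1.2-fold lower number from compound 2 to compound 4 (0.08 log units; that floor lies within the scatter) and an at least 1.2-fold lower number from compound 1 to compound 4 (0.08 log units; that floor lies within the scatter), so the data set no firm order between those groups and 3,5-dimethoxyphenyl. Compound 1 and compound 2 each hold a limit of the assay and not a number: the limit of > 30000 nM in this assay, at which 2 of the 4 values shown sit.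

The compounds shown leave open whether a phenyl group carrying a morpholine, a piperazine or a carboxylic acid would give a number separated from compound 3 by more than the scatter in this assay. Also open, from the compounds shown here alone, is whether a change elsewhere on the shared core, such as a nitrile in place of the trifluoromethyl, would move the number at all.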